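From methylamino to phenyl on the shared core

The source may hold more compounds than are shown below. What is called first, only, known or untested is meant among the compounds shown, and "the series" means these compounds.

Measured in a physicochemical assay for solubility, measured as kinetic solubility; a lower number here means a less soluble compound, a higher number a more soluble compound 
- compound 1 `CNc1ccnc2c(O)c(-c3nc(C)n[nH]3)ncc12` gives > 250000 nM 
- compound 2 `Cc1n[nH]c(-c2ncc3c(NCc4ccc(Cl)cc4)ccnc3c2O)n1` gives 219000 nM 

Compound 1 reads > 250000 nM, which is a limit of the assay and not a number. Its exact place on the scale is therefore unknown.

Compound 3 `Cc1n[nH]c(-c2ncc3c(-c4ccccc4)ccnc3c2O)n1` has not yet been measured. Its change from compound 1 is phenyl in place of methylamino on an aromatic carbon, opposite the ring nitrogen: phenyl in place of methylamino on an aromatic carbon.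

For the measured compounds named here, only one measured step bears on this, and only indirectly. It is an at least 1.1-fold lower number from compound 1 to compound 2 (0.05 log units; that floor lies within the scatter), with 4-chlorophenyl in place of hydrogen on a saturated chain carbon bound to a nitrogen on an aromatic ring. Going by the values given here, that step keeps the nitrogen, whereas compound 3 loses it, and no measured step replaces the methylamino itself. A larger step than that floor is therefore expected, towards a lower number in this assay, though with wide uncertainty.

The expected step is an at least 2.0-fold lower number from compound 1 to compound 3 (0.31 log units; beyond the scatter).

For compound 3 the estimated value is 120000 nM, with an expected range from 40000 nM to 250000 nM.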

Compound 3, solubility: 160000 nM
Estimate against measurement, compound 3: 1.3-fold (0.12 log units) below; measured number inside the range.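

Compound 3 is the first compound shown in which the methylamino itself is replaced, with phenyl on the aromatic carbon opposite the ring nitrogen, and in this assay compound 3 gives 160000 nM, a number and not a limit. The change reads as an at least 1.5-fold lower number from compound 1 to compound 3 (0.19 log units; that floor lies within the scatter), so the result does not establish a drop beyond the scatter, although it does not exclude one. The true size of the step remains unknown because the reading for compound 1 is a limit and not a number: the limit of > 250000 nM in this assay, at which 1 of the 3 values shown sits.

Compound 3 removes the nitrogen on that carbon and brings in the aromatic ring in a single change, so the share of each in the reading remains unseparated. Also open, from the compounds shown here alone, is how a pyridyl ring, a morpholine or a carboxylic acid on the same carbon would read in this assay.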